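This account rests on a few compounds, and the source may have more. Where it says the series, first, only, none or still open, it means among the compounds named here.

Series notes. For the measured compounds named here, compound 3 `CCC(CC)Nc1nc(C)c(-c2ccc(OC(F)F)cc2Cl)nc1OC` gives in an assay on IMR-32 cells for displacement of a labelled ligand from corticotropin-releasing factor receptor 1 (Homo sapiens), read by scintillation counting, with a stated time of 2 h (a higher number here means a weaker inhibitor, a lower number a stronger inhibitor), a value of 4.6 nM, the lowest of the three numbers so far. Compound 2 `CCc1nc(NC(CC)CC)c(OC)nc1-c1ccc(Cl)cc1Cl` gives in this assay 5.9 nM, within the scatter of compound 3, so no order between the two can be read. Compound 1 `CCC(CC)Nc1nc(C)c(-c2ccc(Cl)cc2Cl)nc1C` gives in this assay 27 nM, beyond the scatter and higher than compound 3. Compound 4 `CCC(CC)Nc1nc(C)c(-c2ccc(Cl)cc2Cl)nc1OC` is not yet measured; it differs from compound 3 by chloro in place of difluoromethoxy on an aromatic carbon. Going by the values given here, no single-change step between measured compounds sizes this change. Compound 2 carries the same two chloro groups on its six-membered aromatic ring of carbon only, and its number is close to that of compound 3: compound 2 gives 5.9 nM. The step is therefore expected to be small, a 1.3-fold higher number from compound 3 to compound 4 (0.12 log units; within the scatter), none beyond the scatter. Compound 4 is estimated at 6 nM, range 2.5 nM to 15 nM.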

Compound 4, inhibition constant: 4.3 nM
Compound 4: middle estimate off by 1.4-fold (0.14 log units), on the high side; the range from low to high includes it.
By their numbers in this assay, from the lowest: compounds 4, 3 and 2 (each within the scatter of the next); then compound 1.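

At this position the change can now be sized in this assay as a 1.1-fold lower number from compound 3 to compound 4 (0.03 log units; within the scatter) and chloro and difluoromethoxy cannot be told apart here. Methoxy in place of methyl on an aromatic carbon stands out, with a 6.3-fold lower number from compound 1 to compound 4 (0.80 log units; beyond the scatter) as the only new step beyond the scatter. Hydrogen in place of methyl on a saturated chain carbon bound to an aromatic carbon gives a 1.4-fold lower number from compound 2 to compound 4 (0.14 log units; within the scatter) and no order can be read for this pair.

From the compounds shown here alone, whether an amine, a nitrile or a longer chain in place of chloro would shift the number beyond the scatter remains open. No measurement shown here bears on the cause of these steps.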